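Isopropyl for trifluoromethyl on the shared core

The source may hold more compounds than are shown below. What is called first, only, known or untested is meant among the compounds shown, and "the series" means these compounds.

Compound 1 `O=c1nc2c(ncn2Cc2ccccc2)c(C#CC2CC2)n1Cc1ccccc1` and compound 2 `O=c1nc2c(ncn2Cc2ccccc2)c(C(F)(F)F)n1Cc1ccccc1` share one core. In a functional assay on K562 cells (Homo sapiens) for cytotoxicity, read by thymidine incorporation, with a stated time of 48 h (on this read-out lower numbers stand for stronger inhibition and higher numbers for weaker inhibition), compound 1 gives 0.2 ug/mL. Compound 2 sits at the limit of > 10 ug/mL in this assay, at which 1 of the 2 values shown sits, so its value > 10 ug/mL is a limit and not a number. Among the compounds with values here, the only measured step is an at least 50-fold higher number from compound 1 to compound 2 (1.69 log units; beyond the scatter). Compound 3 `CC(C)c1c2ncn(Cc3ccccc3)c2nc(=O)n1Cc1ccccc1` differs from compound 2 by isopropyl in place of trifluoromethyl on an aromatic carbon. No measured step covers isopropyl; the one step shown compares 2-cyclopropylethynyl with trifluoromethyl and nothing else. Compound 3 is therefore expected near 5 ug/mL, within 0.8 ug/mL to 30 ug/mL, an expected step of an at least 2.0-fold lower number from compound 2 to compound 3 (0.30 log units; that floor lies within the scatter) toward stronger inhibition, with wide uncertainty.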

Compound 3, half-maximal inhibitory concentration: > 10 ug/mL
Compound 3: only a limit was reported; the forecaster's own chance of this, stated with the estimate: 40%; at least 2.0-fold (0.30 log units) between middle value and limit.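

Isopropyl at this position, like trifluoromethyl, falls well short of 2-cyclopropylethynyl in this assay, with an at least 50-fold higher number from compound 1 to compound 3 (1.69 log units; beyond the scatter). The weak result is therefore not particular to trifluoromethyl, and among the three groups shown only 2-cyclopropylethynyl gives a value that is not a limit. The step between compound 2 and compound 3 cannot be read, since both values are limits: the limit of > 10 ug/mL in this assay, at which 2 of the 3 values shown sit.

Going by these compounds, it remains open whether the activity of compound 1 depends on the alkyne or on its cyclopropyl end, which a plain ethynyl or a phenylethynyl group would help separate. On these data alone, how an amine would read at this position is also open.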